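A few compounds are considered here, and "the series" means these few. Any claim that something is new, unique, unknown or untested is made for them only; others in the source may bear on it.

Three compounds sharing one core were measured in an assay on CHO cells for displacement of a labelled ligand from adenosine receptor A1 (Homo sapiens), read by scintillation counting, tested at 10 uM; on this read-out higher numbers stand for more inhibition at the one concentration tested (going by the name of the read-out) and lower numbers for less inhibition:

Compound 1 `CC(C)(C)Cc1c(-c2ccncc2)sc(N)c1C(=O)c1ccc(Cl)cc1`: 1%
Compound 2 `CC(C)(C)Cc1c(Br)sc(N)c1C(=O)c1cccc(C(F)(F)F)c1`: 1%
Compound 3 `COc1ccc(-c2sc(N)c(C(=O)c3ccc(C)cc3)c2CC(C)(C)C)cc1`: 1%

On these numbers compound 1 stands level with compound 2 and with compound 3; the values read the same at the digits reported, and any gap between them lies within the scatter of repeated measurements. None of the three shows more than a trace of displacement in this assay at the single concentration used.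

Compound 4 `CC(C)(C)Cc1c(-c2cn[nH]c2)sc(N)c1C(=O)c1ccc(Cl)cc1` has not yet been measured in this assay. It differs from compound 1 in one place: 1H-pyrazol-4-yl in place of pyridin-4-yl on an aromatic carbon. Going by the values given here, no step between two measured compounds that differ in only one place is available, so there is no measured precedent for this exchange. The three measured compounds, each carrying a different group at the same aromatic carbon, all sit at the bottom of the scale, which gives no sign that this position moves the read-out.

The step from compound 1 to compound 4 is therefore expected to be a number 2 percentage points higher from compound 1 to compound 4 (within the scatter), that is, none beyond the scatter. For compound 4 the value in this assay is estimated at 3%, within a range from -6% to 15%.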

Compound 4, a percentage reported as inhibition, at one concentration (the size of the read-out at that concentration, not a potency): 1%
Compound 4: the middle estimate sits 2 percentage points above what was measured, within the range that was stated.
By their numbers in this assay, from the lowest: compounds 1, 2, 3 and 4 (each within the scatter of the next).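

In this assay, placing 1H-pyrazol-4-yl in place of pyridin-4-yl on the aromatic carbon next to the ring sulfur gives no change at the digits printed from compound 1 to compound 4 (within the scatter). Going by these compounds alone, this is the first comparison in which only the group at this position differs, whereas the earlier compounds also differed elsewhere, and it shows that exchanging a six-membered aromatic ring with 1 hetero atom for a five-membered one with 2 hetero atoms, which also adds a hydrogen-bond donor, leaves the read-out at the bottom of the scale. Nothing available accounts for this lack of movement.

With every compound at the same low level, the compounds shown leave open whether this position can influence displacement in a compound that shows clear inhibition at the tested concentration. They also leave open whether a different group at this carbon, such as a carboxylic acid or an aminomethyl group, or a replacement of the neopentyl group by a longer chain or a benzyl group, would lift the read-out above that level.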